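The compounds below may be only part of what the source reports. "The series", "measured", "known", "first", "only" and "open" are said of these compounds alone.

Measured so far:
compound 1, `CC(C)(C)Cn1cc2c(Cl)nc(NC(=O)c3ccc(C(F)(F)F)cc3)nc2n1` — 6600 nM
compound 2, `Cn1cc2c(Cl)nc(N)nc2n1` — > 100000 nM

Of the compounds shown here, two have been tested in an assay on CHO cells for displacement of a labelled ligand from adenosine receptor A3 (Homo sapiens), read by scintillation counting, with a stated time of 3 h; a higher number here means a weaker inhibitor, a lower number a stronger inhibitor. Compound 1, the larger of the pair, gives 6600 nM. Compound 2 gives > 100000 nM, which is a limit of the assay rather than a number. Compound 2 therefore stands at the limit of > 100000 nM in this assay, at which 1 of the 2 values shown sits: the assay could not read an inhibition constant for it at all, so its position on the scale is known only as lying beyond the readable range.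

Compound 3, `CC(C)n1cc2c(Cl)nc(N)nc2n1`, has not yet been measured. It differs from compound 2 in a single place: isopropyl in place of methyl on an aromatic nitrogen. The rest of the structure is unchanged.

Within the data shown here, no step between two measured compounds of this kind exists here, so the effect of the change has to be guessed rather than read. A change of this size, on a compound already at the limit, is expected to shift the value by a number no higher from compound 2 to compound 3 (the limit leaves the size open), no more than the usual scatter, and in no clear direction. Compound 3 is therefore expected to come out near 100000 nM, somewhere between 25000 nM and 400000 nM, with a real chance that the assay again reports only a limit.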

Compound 3, inhibition constant: > 100000 nM
Compound 3: only a limit was reported (the forecaster's own chance of this, stated with the estimate: 65%); the middle value sits exactly at the limit.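

Compound 2 and compound 3 each end in a limit of the assay rather than a number, so no step between them can be read in this assay: the limit of > 100000 nM in this assay, at which 2 of the 3 values shown sit.

As far as these compounds go, what stays open is how far past that limit each compound lies, and whether isopropyl in place of methyl on an aromatic nitrogen changes the inhibition constant at all.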